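The compounds below may be only part of what the source reports. "The series", "measured", "known", "first", "only" and "open" are said of these compounds alone.

Three close relatives of one scaffold have been tested. Compound 3 `O=C1c2ccccc2C(=O)N1C/C=C/Cn1cc(C#CCCc2ccccc2)c(=O)[nH]c1=O` and compound 1 `CCCCc1ccc(C#Cc2cn(C/C=C/CN3C(=O)c4ccccc4C3=O)c(=O)[nH]c2=O)cc1` carry a double bond drawn E, while compound 2 `O=C1c2ccccc2C(=O)N1C/C=C\Cn1cc(C#CCCc2ccccc2)c(=O)[nH]c1=O` holds the same atoms with that bond drawn Z. In a functional assay on L1210 cells (Mus musculus) for antiproliferative activity, read by MTT assay, with a stated time of 2 days (on this read-out higher numbers stand for weaker inhibition and lower numbers for stronger inhibition), compound 3 gives 44000 nM, compound 1 gives 42000 nM, and compound 2 gives 143000 nM. Going from compound 3 to compound 1 means (4-butylphenyl in place of phenethyl on a triple-bonded carbon), and the outcome was a 1.0-fold lower number from compound 3 to compound 1 (0.02 log units; within the scatter), a flat result. The two cores differ only as the two compounds have the same atoms and bonds and differ only in configuration as drawn: 1 of 1 stereo elements differ; a double bond is drawn E in compound 3 and Z in compound 2; the measured step was a 3.3-fold lower number from compound 2 to compound 3 (0.51 log units; beyond the scatter), and the one thing that can be pointed to for it is the fact that compounds 2 and 3 differ only in the configuration as drawn. Compound 4 `CCCCc1ccc(C#Cc2cn(C/C=C\CN3C(=O)c4ccccc4C3=O)c(=O)[nH]c2=O)cc1` has not been tested; it is built from compound 2 by 4-butylphenyl in place of phenethyl on a triple-bonded carbon, the same change as the earlier one, since the place where it occurs is described in identical words. Resting on the flat pair of compound 3 at 44000 nM and compound 1 at 42000 nM, the expected step is a 1.0-fold lower number from compound 2 to compound 4 (0.01 log units; within the scatter) in this assay. Compound 4 is therefore estimated at 140000 nM, with a likely range from 70000 nM to 280000 nM.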

Compound 4, half-maximal inhibitory concentration: 31000 nM
Compound 4: middle estimate off by 4.5-fold (0.65 log units), on the high side; measured number below the stated range.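

Swapping phenethyl for 4-butylphenyl does not carry over unchanged from the core with the double bond drawn E to the one with it drawn Z. In this assay the swap gives a 4.6-fold lower number from compound 2 to compound 4 (0.66 log units; beyond the scatter) on the Z core, while the same swap was flat on the E core: the same change on two cores in this assay, a 1.0-fold lower number (0.02 log units; within the scatter) from compound 3 to compound 1 and a 4.6-fold lower number (0.66 log units; beyond the scatter) from compound 2 to compound 4, 4.4-fold (0.64 log units) apart, beyond the scatter of two such steps. With 4-butylphenyl in place, turning the double bond from E to Z gives a 1.4-fold lower number from compound 1 to compound 4 (0.13 log units; within the scatter) and so lies within the scatter, unlike the clear gap seen with phenethyl: the fact that compounds 1 and 4 differ only in the configuration as drawn. Going by these compounds alone, this shows that the size of the step depends on the core in these four compounds, but it rests on only two pairs and does not reveal the cause, so it gives no rule for other groups.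

The compounds shown leave open how other groups on the triple-bonded carbon would behave on the two cores. A longer chain, an amine or a carboxylic acid there could show whether the E and Z cores usually respond differently or whether 4-butylphenyl is a special case.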